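Methoxy in place of hydrogen on the anilino ring

The source may hold more compounds than are shown below. What is called first, only, known or untested is meant among the compounds shown, and "the series" means these compounds.

Compound 3 `CC(C)c1ccc(-c2nc(SCc3cn(CC(=O)NC(=O)Nc4ccccn4)nn3)nc(Nc3ccccc3)c2C#N)cc1` is the unsubstituted anilino member of the three measured compounds. In a functional assay on ECa-109 cells (Homo sapiens) for inhibition, read by MTT assay, with a stated time of 72 h (a lower number here means a stronger inhibitor, a higher number a weaker inhibitor), compound 3 gives > 64000 nM, which is a limit of the assay and not a number. This is the limit of > 64000 nM in this assay, at which 1 of the 3 values shown sits. Compound 1 `CC(C)c1ccc(-c2nc(SCc3cn(CC(=O)NC(=O)Nc4ccccn4)nn3)nc(Nc3cccc(Cl)c3)c2C#N)cc1` gives 13300 nM in this assay, and compound 2 `CC(C)c1ccc(-c2nc(SCc3cn(CC(=O)NC(=O)Nc4ccccn4)nn3)nc(Nc3ccccc3F)c2C#N)cc1` gives 15500 nM; the two sit within the scatter of each other (a 1.2-fold higher number from compound 1 to compound 2 (0.07 log units; within the scatter)). Both carry a halogen on the anilino ring that compound 3 lacks, and removing it weakens inhibition in each case: an at least 4.8-fold higher number from compound 1 to compound 3 (0.68 log units; beyond the scatter) and an at least 4.1-fold higher number from compound 2 to compound 3 (0.61 log units; beyond the scatter), both beyond the scatter.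

Compound 4 `COc1ccccc1Nc1nc(SCc2cn(CC(=O)NC(=O)Nc3ccccn3)nn2)nc(-c2ccc(C(C)C)cc2)c1C#N` differs from compound 3 in one place: methoxy in place of hydrogen on an aromatic carbon, the entering group standing ortho to a large group. The steps from compound 1 and compound 2 to compound 3 are the ones that bear on this change, as each replaces a substituent on the anilino ring with hydrogen and each raises the number by a modest amount. A substituent entering at the same ring is therefore expected to move the number downward again in this assay, by a step of about an at least 3.2-fold lower number from compound 3 to compound 4 (0.50 log units; beyond the scatter), though the limit for compound 3 leaves its exact size open. Compound 4 is estimated at 20000 nM, with a range from 8000 nM to 60000 nM.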

Compound 4, half-maximal inhibitory concentration: 8960 nM
Compound 4: the middle estimate sits 2.2-fold (0.35 log units) above what was measured; measured number inside the range.
By their numbers in this assay, from the lowest: compounds 4, 1 and 2 (each within the scatter of the next). At a limit, above all of these: compound 3.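

In this assay, methoxy in place of hydrogen on the anilino ring gives an at least 7.1-fold lower number from compound 3 to compound 4 (0.85 log units; beyond the scatter), so among these compounds the recovery from the unsubstituted member is not confined to halogens. The methoxy compound cannot be separated from the two halogen compounds, with a 1.7-fold lower number from compound 2 to compound 4 (0.24 log units; within the scatter) and a 1.5-fold lower number from compound 1 to compound 4 (0.17 log units; within the scatter), so in these four compounds having a substituent on this ring counts for more than which of the three it is. The value of compound 3 is a limit and not a number, which leaves the full size of the gain from methoxy unfixed: the limit of > 64000 nM in this assay, at which 1 of the 4 values shown sits.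

Going by these compounds, whether an amine, a hydroxyl or a longer chain such as ethoxy in place of methoxy would stay in this range in this assay remains open. Methoxy, fluoro and chloro each appear at only one place on the ring, so the effect of the place cannot be separated from the effect of the group.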